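A few compounds are considered here, and "the series" means these few. Any claim that something is new, unique, unknown or untested is made for them only; others in the source may bear on it.

Compound 1 `CCOc1ccc(Cc2nnc(CN(c3cccc(Cl)c3C)S(=O)(=O)c3ccc(C)cc3)o2)cc1` gives 50.1 nM in a functional assay on CHO cells for antagonist activity at prostaglandin E2 receptor EP1 subtype (Homo sapiens), read by FLIPR and calcium flux; on this read-out higher numbers stand for weaker inhibition and lower numbers for stronger inhibition.
Compound 2 `Cc1ccc(S(=O)(=O)N(Cc2nnc(Cc3ccc(N(C)C)cc3)o2)c2cccc(Cl)c2C)cc1` gives 20 nM in this assay.

Among the measured compounds shown here, compound 2 holds the lower of the two numbers measured so far; its nearest neighbour is compound 1, and the only step between measured compounds, a 2.5-fold lower number from compound 1 to compound 2 (0.40 log units; beyond the scatter), separates them. Compound 3 `Cc1ccc(S(=O)(=O)N(Cc2nnc(Cc3ccc(F)cc3)o2)c2cccc(Cl)c2C)cc1` has not yet been tested. It differs from compound 2 by fluoro in place of dimethylamino on an aromatic carbon, a change on an aromatic carbon of a six-membered aromatic ring of carbon only, para to a large group. For the measured compounds named here, the one measured step that bears on this position, a 2.5-fold lower number from compound 1 to compound 2 (0.40 log units; beyond the scatter), shows that the dimethylamino group went with a modestly lower number than the ethoxy group. Fluoro is neither of these, and no measured pair shows what fluoro does at this position. The step is therefore expected to give back part of that gain: a modest rise in the number, roughly back toward where compound 1 sits, though a result within the scatter of compound 2 cannot be ruled out. For compound 3 the expected step is a 3.0-fold higher number from compound 2 to compound 3 (0.48 log units; beyond the scatter). Compound 3 is estimated at 60 nM in this assay, with a range from 20 nM to 180 nM.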

Compound 3, inhibition constant: 501 nM
Estimate against measurement, compound 3: 8.4-fold (0.92 log units) below, outside the stated range (above it).
By their numbers in this assay, from the lowest: compound 2; then compound 1; then compound 3.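

In this assay, among the compounds shown here, the group on this aromatic carbon, para to a large group, matters far more than the single earlier step could show: replacing dimethylamino with fluoro brings a 25-fold higher number from compound 2 to compound 3 (1.40 log units; beyond the scatter) and replacing ethoxy with fluoro brings a 10-fold higher number from compound 1 to compound 3 (1.00 log units; beyond the scatter) in the same direction. The earlier gap of a 2.5-fold lower number from compound 1 to compound 2 (0.40 log units; beyond the scatter) is therefore only the smaller part of the span seen at this position, and the three groups now fall in a clear order, with dimethylamino giving the lowest number, ethoxy the middle one and fluoro the highest, each step lying beyond the scatter. What lies behind this order cannot be said, as nothing measured here speaks to why fluoro gives so much weaker inhibition than the other two groups.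

The three compounds leave open where other groups would fall in this order, such as an unsubstituted amino group, diethylamino, methoxy or a plain hydrogen on the same carbon. They also leave open whether the same order would hold if the rest of the shared core were changed.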